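Replacing Trifluoromethyl with Fluorophenyl: Expected Cytotoxicity

The source may hold more compounds than are shown below. What is called first, only, known or untested is meant among the compounds shown, and "the series" means these compounds.

Three compounds share one core and differ only in the group on one aromatic carbon. Compound 1 `C[C@]1(CN2CCc3nc(-c4ccccc4)ccc3C2)Cn2cc([N+](=O)[O-])nc2O1` carries an unsubstituted phenyl ring, compound 2 `C[C@]1(CN2CCc3nc(N4CCCCC4)ccc3C2)Cn2cc([N+](=O)[O-])nc2O1` a saturated nitrogen ring, and compound 3 `C[C@]1(CN2CCc3nc(C(F)(F)F)ccc3C2)Cn2cc([N+](=O)[O-])nc2O1` a trifluoromethyl group. In an ADME assay on Vero cells (Chlorocebus sabaeus) for cytotoxicity, read by MTT assay, with a stated time of 72 h (on this read-out lower numbers stand for higher toxicity in this test and higher numbers for lower toxicity in this test), compound 1 gives > 32 ug/mL, which is a limit of the test rather than a number, as noted in the limit of > 32 ug/mL in this assay, at which 1 of the 3 values shown sits. In this assay compound 2 gives "not determined" (no result reported). In this assay compound 3 likewise gives "not determined" (no result reported), so compound 3 has no measured position on this read-out at all.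

The step to compound 4 `C[C@]1(CN2CCc3nc(-c4cccc(F)c4)ccc3C2)Cn2cc([N+](=O)[O-])nc2O1` is 3-fluorophenyl in place of trifluoromethyl on an aromatic carbon. No measured step between any two of these compounds exists in this assay, so nothing shows how such a change moves the read-out. The expectation rests on the fact that the closest measured relative, compound 1, reached only the limit, and on the absence of any evidence pointing to a larger or smaller number beyond the scatter.

Compound 4 is expected to give about 40 ug/mL in this assay, with a plausible range from 16 ug/mL to 100 ug/mL.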

Compound 4, half-maximal cytotoxic concentration: > 32 ug/mL
Compound 4 ended at the assay's limit (the forecaster's own chance of this, stated with the estimate: 70%); the middle value is on the limit's open side.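

For the compounds shown here, compound 1 and compound 4 both stop at the same limit of the test rather than at a number, so no step between them can be read: the limit of > 32 ug/mL in this assay, at which 2 of the 4 values shown sit.

The compounds shown leave open how far either lies past that limit, and whether fluoro in place of hydrogen changes the result in this assay at all.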